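The compounds below may be only part of what the source reports. "The series", "measured", "known", "first", "only" and "open" are said of these compounds alone.

Of the compounds shown here, two built on one shared core have been tested in a functional assay on UACC-62 cells (Homo sapiens) for inhibition, read by sulforhodamine B assay, with a stated time of 48 h; a higher number here means that more compound is tolerated, a lower number that less compound is tolerated. Compound 1 `COc1ccc(CNc2nc3cc(N)cc(N)c3nc2-c2ccccc2)cc1OC` gives 53700 nM. Compound 2 `COc1ccc(Sc2nc3cc(N)cc(N)c3nc2-c2ccccc2)cc1` reaches only a limit of the assay, < 100000 nM. So on the numbers shown compound 2 has no fixed place: what is known is just that it sits at the limit of < 100000 nM in this assay, at which 1 of the 2 values shown sits, and nothing more. Compound 3 `Nc1cc(N)c2nc(-c3ccccc3)c(Sc3ccc(F)cc3)nc2c1` is the one still to be measured; it differs from compound 2 by fluoro in place of methoxy on an aromatic carbon. Within the data shown here, no step between two measured compounds is available here, so there is no precedent for how large such an exchange turns out in this assay. With compound 2 known only as a limit, the step that the limit leaves unreadable from compound 2 to compound 3 is expected to stay within the usual scatter, in no particular direction. Compound 3 is therefore estimated at 55000 nM, with a range from 20000 nM to 100000 nM.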

Compound 3, concentration lethal to 50% of the cells: 60300 nM
For compound 3 the middle estimate is 1.1-fold (0.04 log units) below the measured one; low and high end bracket the measured number.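

Among these compounds, no step from compound 2 to compound 3 can be read, because compound 2 is known only as a limit and not as a number: the limit of < 100000 nM in this assay, at which 1 of the 3 values shown sits. From the compounds shown here alone, how far fluoro in place of methoxy on an aromatic carbon shifts the result in this assay therefore stays open.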